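Swapping a Benzyl for a Phenoxy Group on the Core

The source may hold more compounds than are shown below. What is called first, only, known or untested is meant among the compounds shown, and "the series" means these compounds.

Among the three compounds measured so far, compound 3 `Cc1ccccc1Cc1nc2cc(O[C@H]3CC[C@@H](C(=O)O)CC3)ccc2n1C` is the weakest: in an assay on isolated protein for inhibition of Long-chain-fatty-acid--CoA ligase 1 (Mus musculus), read by mass spectrometry, with a stated time of 90 min, in the presence of a further agent that is not named here (a higher number here means a weaker inhibitor, a lower number a stronger inhibitor), compound 3 gives 5400 nM, whereas compound 1 `Cc1cccc(Cn2nc3cc(O[C@H]4CC[C@@H](C(=O)O)CC4)ccc3c2C)c1` gives 53 nM and compound 2 `Cc1cccc(Cc2cc3cc(O[C@H]4CC[C@@H](C(=O)O)CC4)ccc3n2C)c1` gives 400 nM, both gaps lying well beyond the usual scatter. Compound 4 `Cc1cccc(Oc2nc3cc(O[C@H]4CC[C@@H](C(=O)O)CC4)ccc3n2C)c1` keeps the core of compound 3 and changes one group: 3-methylphenoxy in place of 2-methylbenzyl on an aromatic carbon. Among the compounds with values here, no pair of measured compounds covers this exact exchange, and compounds 1 and 2 differ from compound 3 in their cores as well, so nothing measured isolates the effect of the new group. The expected step is a 2.7-fold lower number from compound 3 to compound 4 (0.43 log units; beyond the scatter), a modest gain that remains uncertain. Compound 4 is estimated at 2000 nM in this assay, with a likely range from 400 nM to 10000 nM.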

Compound 4, half-maximal inhibitory concentration: 21000 nM
The estimate for compound 4 lay 11-fold (1.02 log units) below the measured number, and the stated range ends below it.
By their numbers in this assay, from the lowest: compound 1; then compound 2; then compound 3; then compound 4.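

Exchanging 2-methylbenzyl for 3-methylphenoxy on this aromatic carbon, between two ring nitrogen atoms, gives a 3.9-fold higher number from compound 3 to compound 4 (0.59 log units; beyond the scatter) on the shared core. So this position responds to the exchange even though both groups hold the same number of heavy atoms, and the new group brings no gain here. No measurement available bears on why the number rises. Going by these compounds, the exchange changes both the link to the ring and the place of the methyl, so which of these matters stays open. 2-Methylphenoxy, or an amine link in place of the oxygen, on this core could help separate them.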